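Ester Swap on a Hydroxamic Acid: Naphthyl to Phenethyl

This account rests on a few compounds, and the source may have more. Where it says the series, first, only, none or still open, it means among the compounds named here.

The measured compounds:
Compound 1, `CC[C@H](C)C(=O)O[C@H]1C[C@@H](C)C=C2C=C[C@H](C)[C@H](CC[C@@H](O)C[C@@H](CC(=O)NO)OC(=O)c3ccc([N+](=O)[O-])cc3)[C@H]21`; in a functional assay on PC-3 cells (Homo sapiens) for inhibition, read by sulforhodamine B assay, with a stated time of 48 h (a lower number here means a stronger inhibitor, a higher number a weaker inhibitor), compound 1 gives 8200 nM.
Compound 2, `CC[C@H](C)C(=O)O[C@H]1C[C@@H](C)C=C2C=C[C@H](C)[C@H](CC[C@@H](O)C[C@@H](CC(=O)NO)OC(=O)c3ccc4ccccc4c3)[C@H]21`; in this assay compound 2 gives 17300 nM.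

Compound 2 holds the highest of the two numbers, that is, it is the weaker of the two inhibitors. Among the measured compounds shown here, its only neighbour is compound 1, and the single measured step between them, a 2.1-fold higher number from compound 1 to compound 2 (0.32 log units; beyond the scatter), is modest but beyond the scatter.

Compound 3, `CC[C@H](C)C(=O)O[C@H]1C[C@@H](C)C=C2C=C[C@H](C)[C@H](CC[C@@H](O)C[C@@H](CC(=O)NO)OC(=O)CCc3ccccc3)[C@H]21`, has not yet been measured. It differs from compound 2 by phenethyl in place of naphthalen-2-yl on a carbonyl carbon. For the measured compounds named here, the one step measured so far exchanged one aromatic group for another on the same carbonyl carbon and moved the number only modestly. Going by the values given here, no measured step replaces an aromatic group with a phenethyl group, so the direction of this change cannot be read from the data. Compound 2 sits at the top of a narrow pair, which slightly favours a number at or a little below it.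

Compound 3 is therefore expected to give about 12000 nM in this assay, within 5000 nM to 30000 nM, an expected step of a 1.4-fold lower number from compound 2 to compound 3 (0.16 log units; within the scatter) that is not confidently beyond the scatter.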

Compound 3, half-maximal inhibitory concentration: 6200 nM
For compound 3 the middle estimate is 1.9-fold (0.29 log units) above the measured one, within the range that was stated.
By their numbers in this assay, from the lowest: compounds 3 and 1 (each within the scatter of the next); then compound 2.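

In this assay, among the compounds shown here, the earlier pair compared only two aromatic groups bonded to this carbonyl carbon, so it could not show what a different kind of group would do. Phenethyl, with one six-membered aromatic ring in place of the two in naphthalen-2-yl, gives a 2.8-fold lower number from compound 2 to compound 3 (0.45 log units; beyond the scatter), so the larger number belongs to compound 2 in particular and is not shared by every group tried at this place. Set against 4-nitrophenyl, phenethyl gives a 1.3-fold lower number from compound 1 to compound 3 (0.12 log units; within the scatter), which leaves compound 1 and compound 3 indistinguishable in this assay and makes compound 2 the weakest of the three, although all the steps at this place remain modest.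

Nothing available explains why naphthalen-2-yl stands apart from the other two groups. The compounds shown leave open whether a longer chain ending in a phenyl ring, or a carboxylic acid or an amine on this carbonyl carbon's side chain, would move the number further in either direction or keep it in the same narrow band.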